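Dropping One Benzyloxy Group from a Weak Inhibitor

A few compounds are considered here, and "the series" means these few. Any claim that something is new, unique, unknown or untested is made for them only; others in the source may bear on it.

Within the data shown here, compound 1 `O=c1cc(/C=N\c2ccccc2O)c2c(OCc3ccccc3)cc(OCc3ccccc3)cc2o1` is the only compound that gives a number in a functional assay, read by spectrophotometry, with a stated time of 3 min (on this read-out higher numbers stand for weaker inhibition and lower numbers for stronger inhibition), where compound 1 gives 7760 nM. Compound 2 `O=c1cc(/C=N\Nc2ccc([N+](=O)[O-])cc2[N+](=O)[O-])c2c(OCc3ccccc3)cc(OCc3ccccc3)cc2o1` was reported in this assay as "not active" (no number reported), with no number attached. Compound 3 `O=c1cc(/C=N\c2ccccc2O)c2ccc(OCc3ccccc3)cc2o1` differs from compound 1 by hydrogen in place of benzyloxy on an aromatic carbon. Among the measured compounds shown here, no measured pair shows such a change, so the size of the step is uncertain; a modest weakening, possibly not beyond the scatter, is expected, a 1.5-fold higher number from compound 1 to compound 3 (0.19 log units; within the scatter). Compound 3 is estimated at 12000 nM, within 4000 nM to 40000 nM.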

Compound 3, half-maximal inhibitory concentration: 1290 nM
Compound 3: the middle estimate sits 9.3-fold (0.97 log units) above what was measured; the whole stated range lies above it.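

In this assay the swap of benzyloxy for hydrogen gives a 6.0-fold lower number from compound 1 to compound 3 (0.78 log units; beyond the scatter) and this step lies beyond the usual scatter. Inhibition therefore grows stronger when this benzyloxy group leaves, so in this pair the group is not needed at this position on the shared core. The other benzyloxy group stays in both compounds, so its own part cannot be read. As far as these compounds go, whether a smaller group here, such as methoxy or a hydroxyl, would keep or extend the gain stays open. No measurement at hand explains the gain.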